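One ring swap, from 3-fluorobenzyl to 4-methylbenzyl

A few compounds are considered here, and "the series" means these few. Any claim that something is new, unique, unknown or untested is made for them only; others in the source may bear on it.

- compound 1 `N#C/C(=C\c1ccccc1OS(=O)(=O)c1ccccc1[N+](=O)[O-])C(=O)Nc1nnc(Cc2cccc3ccccc23)s1`: 23%
- compound 2 `N#C/C(=C\c1ccccc1OS(=O)(=O)c1ccccc1[N+](=O)[O-])C(=O)Nc1nnc(Cc2cccc(F)c2)s1`: 23%

In a functional assay on HL-60 cells (Homo sapiens) for inhibition, read by CCK-8 assay, with a stated time of 48 h, tested at 20 uM (a higher number here means more inhibition of growth at the concentration tested, a lower number less inhibition of growth), compound 2 gives 23%, level with compound 1 at 23%. The next compound, compound 3 `Cc1ccc(Cc2nnc(NC(=O)/C(C#N)=C/c3ccccc3OS(=O)(=O)c3ccccc3[N+](=O)[O-])s2)cc1`, differs from compound 2 in one group: 4-methylphenyl in place of 3-fluorophenyl on a saturated chain carbon bound to an aromatic carbon. Among the compounds with values here, only one measured step changes the group at this same place: no change at the digits printed from compound 1 to compound 2 (within the scatter). Even that swap of a naphthalen-1-yl group moved nothing, so no step beyond the scatter is expected in this assay here. The estimated step is no change at the digits printed from compound 2 to compound 3 (within the scatter). Compound 3 is expected at about 23%, within an estimated range of 11% to 38%.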

Compound 3, percent growth inhibition at one concentration: 33%
Compound 3: the middle estimate sits 10 percentage points below what was measured; low and high end bracket the measured number.
By their numbers in this assay, from the lowest: compounds 1, 2 and 3 (each within the scatter of the next).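

In this assay the swap to 4-methylphenyl gives a number 10 percentage points higher from compound 2 to compound 3 (within the scatter) and a number 10 percentage points higher from compound 1 to compound 3 (within the scatter). So naphthalen-1-yl, 3-fluorophenyl and 4-methylphenyl on this saturated chain carbon all stay within the scatter of one another, and no change of aromatic ring shown here separates any pair. Nothing available explains these numbers.

From the compounds shown here alone, whether an amine or a carboxylic acid at this place would give a step beyond the scatter remains open. So does the effect of a longer chain carrying the ring.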